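Replacing the 1,3-thiazol-2-yl group of compound 3

The source may hold more compounds than are shown below. What is called first, only, known or untested is meant among the compounds shown, and "the series" means these compounds.

Three close relatives share one core and differ in a single group on an aromatic carbon. In a functional assay on SK-MEL-28 cells (Homo sapiens) for cytotoxicity, read by MTT assay, with a stated time of 3 days (on this read-out higher numbers stand for weaker inhibition and lower numbers for stronger inhibition), compound 1 `N#Cc1c(O)nc(SCc2nc3ccccc3[nH]2)nc1-c1ccccc1` gives 7.7 nM as its reading. Compound 2 `N#Cc1c(NN)nc(SCc2nc3ccccc3[nH]2)nc1-c1ccccc1` gives 3 nM on the same read-out. Compound 3 `N#Cc1c(Nc2nccs2)nc(SCc2nc3ccccc3[nH]2)nc1-c1ccccc1` gives 8.9 nM and so sits level with compound 1 within the scatter, while compound 2 stands clearly lower.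

Compound 4 `N#Cc1c(NC(N)=S)nc(SCc2nc3ccccc3[nH]2)nc1-c1ccccc1` keeps the core of compound 3 and changes one group: a group of 3 heavy atoms (1 carbon, 1 nitrogen, 1 sulfur; no ring) in place of a group of 5 heavy atoms (3 carbon, 1 nitrogen, 1 sulfur; one five-membered aromatic ring with 2 hetero atoms), on a nitrogen on an aromatic ring is the whole difference. The incoming group has no ring.

The nearest guide is a 3.0-fold higher number from compound 2 to compound 3 (0.47 log units; beyond the scatter) where 1,3-thiazol-2-yl took the place of amino on the same nitrogen. Removing that ring might therefore lower the number somewhat. The other guides are milder: a 1.2-fold higher number from compound 1 to compound 3 (0.06 log units; within the scatter) is no real change, and a 2.6-fold lower number from compound 1 to compound 2 (0.41 log units; beyond the scatter) is modest. All three compounds lie close together, so only a small move seems likely.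

The expected change is a 1.5-fold lower number from compound 3 to compound 4 (0.17 log units; within the scatter) and this estimated step is slightly downward, probably inside the scatter. Compound 4 is expected at 6 nM with an estimated range of 2.5 nM to 15 nM in this assay once tested.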

Compound 4, half-maximal inhibitory concentration: 4.8 nM
Compound 4: the middle estimate sits 1.3-fold (0.10 log units) above what was measured; low and high end bracket the measured number.
By their numbers in this assay, from the lowest: compounds 2, 4, 1 and 3 (each within the scatter of the next, the first and the last beyond it).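

In this assay, the step to the ringless group gives a 1.9-fold lower number from compound 3 to compound 4 (0.27 log units; within the scatter), so on this nitrogen on an aromatic ring the five-membered aromatic ring of 1,3-thiazol-2-yl can give way to an open group without a change beyond the scatter. The new group also leaves compound 4 level with both neighbours, with a 1.6-fold higher number from compound 2 to compound 4 (0.20 log units; within the scatter) and a 1.6-fold lower number from compound 1 to compound 4 (0.21 log units; within the scatter), so it falls within the scatter of compound 2 and compound 1 alike, while the gap between compound 2 and compound 3 remains the only one beyond the scatter. No measurement here offers a reason for these readings.

From the compounds shown here alone, it remains open whether the sulfur of the incoming group matters, which an oxygen in its place would test, and whether a plain ethyl chain or a morpholine ring on the same nitrogen would hold the reading in the same narrow band. With only four close relatives on one core, nothing shows how far this tolerance for different groups extends, or whether a carboxylic acid at this place would break it.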